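Oxindole-triazole series: E to Z configuration at compound 3

The compounds below may be only part of what the source reports. "The series", "measured", "known", "first", "only" and "open" are said of these compounds alone.

Measured so far:
- Compound 1, `O=C1Nc2ccc(Cl)cc2/C1=C/c1cccc(OCc2cn(Cc3ccccc3)nn2)c1`, in a functional assay on HeLa cells (Homo sapiens) for inhibition, read by MTT assay, with a stated time of 48 h (a higher number here means a weaker inhibitor, a lower number a stronger inhibitor), gives "not determined" (no result reported).
- Compound 2, `CC(=O)c1ccc2c(c1)/C(=C/c1cccc(OCc3cn(Cc4ccccc4)nn3)c1)C(=O)N2`, in this assay gives > 50000 nM.
- Compound 3, `COc1ccc(Cc2ccc3c(c2)/C(=C\c2cccc(OCc4cn(Cc5ccccc5)nn4)c2)C(=O)N3)cc1`, in this assay gives "not determined" (no result reported).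

The value for compound 2 is a limit of this assay and not a number. Where compound 3 stands therefore cannot be read from a number of its own: one further entry is a limit and one further entry has no single number, so compound 3 has no fixed place among the values shown. One of the three entries sits at the limit described by the limit of > 50000 nM in this assay, at which 1 of the 3 values shown sits.

Compound 4, `COc1ccc(Cc2ccc3c(c2)/C(=C/c2cccc(OCc4cn(Cc5ccccc5)nn4)c2)C(=O)N3)cc1`, is the next member. The change from compound 3 is the two compounds have the same atoms and bonds and differ only in configuration as drawn: 1 of 1 stereo elements differ; a double bond is drawn E in compound 3 and Z in compound 4; in words, the two compounds have the same atoms and bonds and differ only in configuration as drawn; a double bond is drawn E in compound 3 and Z in compound 4. Among the measured compounds shown here, no step between measured compounds is available in this assay to anchor this change, so the expected step is taken as none beyond the scatter, with no direction assigned.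

Compound 4 is expected to give about 30000 nM in this assay, estimated between 5000 nM and 100000 nM.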

Compound 4, half-maximal inhibitory concentration: 7700 nM
Estimate against measurement, compound 4: 3.9-fold (0.59 log units) above; the measured number falls inside the stated range.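

In this assay, among the compounds shown here, compound 4 gives the first single number, 7700 nM, and 4-methoxybenzyl in place of acetyl on the aromatic carbon gives an at least 6.4-fold lower number from compound 2 to compound 4 (0.81 log units; beyond the scatter). The entry for compound 2, > 50000 nM, is a limit of the assay and not a number. The E to Z change itself cannot be read, as compound 3 has no result in this assay, so this pair offers only its structural relation: the fact that compounds 3 and 4 differ only in the configuration as drawn.

On these data alone, whether the double-bond configuration matters in this assay remains open, for the 4-methoxybenzyl compounds and for the rest of the series. Also open, as far as these compounds go, is how an amine or a carboxylic acid on the same aromatic carbon would read against 4-methoxybenzyl and acetyl.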